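A few compounds are considered here, and "the series" means these few. Any claim that something is new, unique, unknown or untested is made for them only; others in the source may bear on it.

Four related compounds were compared in a functional assay on MCF7 cells (Homo sapiens) for cytotoxicity, read by sulforhodamine B assay, with a stated time of 72 h; on this read-out lower numbers stand for stronger inhibition and higher numbers for weaker inhibition. Compound 1 `CC(=O)OC[C@H]1O[C@@H](OC2=CC(=O)c3ccccc3C2=O)[C@H](OC(C)=O)[C@@H](OC(C)=O)[C@@H]1OC(C)=O` gives 4760 nM in this assay. Compound 2 `CC(=O)N[C@H]1[C@H](OC2=CC(=O)c3ccccc3C2=O)O[C@H](COC(C)=O)[C@@H](OC(C)=O)[C@@H]1OC(C)=O` differs from it by one change, (acetamido in place of acetoxy on a saturated ring carbon), and in this assay compound 2 gives 16300 nM, so the change produced a 3.4-fold higher number from compound 1 to compound 2 (0.53 log units; beyond the scatter).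

Compound 3 `CC(=O)OC[C@H]1O[C@@H](n2cc(COC3=CC(=O)c4ccccc4C3=O)nn2)[C@H](OC(C)=O)[C@@H](OC(C)=O)[C@@H]1OC(C)=O` carries a different core; how its core differs from that of compound 1 is not broken down here. In this assay compound 3 gives 3330 nM. Compared with compound 1 its value lies within the scatter of the method, while against compound 2 the gap is beyond the scatter.

Compound 4 `CC(=O)N[C@@H]1[C@@H](OC(C)=O)[C@H](OC(C)=O)[C@@H](COC(C)=O)O[C@H]1n1cc(COC2=CC(=O)c3ccccc3C2=O)nn1` has not yet been measured. It stands to compound 3 as compound 2 stands to compound 1: the change is acetamido in place of acetoxy on a saturated ring carbon, the same change made on the same surroundings in the ring. Resting on the step seen from compound 1 to compound 2, a weakening of similar size is expected from compound 3 to compound 4, that is a 2.9-fold higher number from compound 3 to compound 4 (0.46 log units; beyond the scatter). On that basis compound 4 is estimated at 9500 nM, most likely between 4000 nM and 25000 nM.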

Compound 4, half-maximal inhibitory concentration: 28900 nM
Estimate against measurement, compound 4: 3.0-fold (0.48 log units) below, and the stated range ends below it.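

In this assay, putting acetamido in place of acetoxy on a saturated ring carbon again shifted the number towards weaker inhibition, with an 8.7-fold higher number from compound 3 to compound 4 (0.94 log units; beyond the scatter). Set beside the earlier step, the change points the same way on both cores, and the two step sizes cannot be told apart: the same change on two cores in this assay, a 3.4-fold higher number (0.53 log units; beyond the scatter) from compound 1 to compound 2 and an 8.7-fold higher number (0.94 log units; beyond the scatter) from compound 3 to compound 4, 2.5-fold (0.40 log units) apart, within the scatter of two such steps. This supports carrying the direction of the change from the core of compound 1 to the core of compound 3, but it does not show that the step is truly larger on the second core, why the change weakens inhibition, or that it would behave alike on a third core.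

The compounds shown leave open what a free hydroxyl, an amine or a longer acylamino chain such as propionamido would do on this same ring carbon. They also leave open whether the step holds in cell lines other than this one.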